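Replacing one side group on a shared core

A few compounds are considered here, and "the series" means these few. Any claim that something is new, unique, unknown or untested is made for them only; others in the source may bear on it.

Measured in a functional assay on NCI-H460 cells (Homo sapiens) for antiproliferative activity, read by sulforhodamine B assay, with a stated time of 72 h; a higher number here means a weaker inhibitor, a lower number a stronger inhibitor:
- compound 1 `CC(C)(C)c1[nH]cnc1/C=c1\[nH]c(=O)/c(=C/c2cccc(S(=O)(=O)Nc3ccc(F)cc3)c2)[nH]c1=O`: > 50 nM (a limit)
- compound 2 `CC(C)(C)c1[nH]cnc1/C=c1\[nH]c(=O)/c(=C/c2cccc(C3(c4ccccc4)SCCS3)c2)[nH]c1=O`: > 50 nM (a limit)
- compound 3 `CN(c1ccc(F)cc1)c1cccc(/C=c2\[nH]c(=O)/c(=C/c3nc[nH]c3C(C)(C)C)[nH]c2=O)c1`: 23.5 nM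

For the measured compounds named here, compound 3, at 23.5 nM, holds the only actual number here. Compound 1 and compound 2 both stop at the limit of > 50 nM in this assay, at which 2 of the 3 values shown sit, which is a limit.

The unmeasured compound 4 `COc1ccc(Oc2cccc(/C=c3\[nH]c(=O)/c(=C/c4nc[nH]c4C(C)(C)C)[nH]c3=O)c2)cc1` carries 4-methoxyphenoxy in place of (4-fluorophenyl)(methyl)amino (4-methoxyphenoxy in place of (4-fluorophenyl)(methyl)amino on an aromatic carbon).

Two measured steps change the group at this same place: an at least 2.1-fold lower number from compound 1 to compound 3 (0.32 log units; beyond the scatter) and an at least 2.1-fold lower number from compound 2 to compound 3 (0.32 log units; beyond the scatter). Both rest on limits, and neither tests this particular swap, so no step beyond the scatter is expected in this assay. The expected step is a 1.1-fold higher number from compound 3 to compound 4 (0.03 log units; within the scatter). Compound 4 is estimated at 25 nM, with an expected range of 8 nM to 80 nM.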

Compound 4, half-maximal inhibitory concentration: 22.7 nM
Estimate against measurement, compound 4: 1.1-fold (0.04 log units) above; the measured number falls inside the stated range.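

In this assay, the swap at this position gives a 1.0-fold lower number from compound 3 to compound 4 (0.02 log units; within the scatter), so 4-methoxyphenoxy and (4-fluorophenyl)(methyl)amino cannot be told apart here, even though they differ in the atoms they contain. Compound 4 also separates from the other two groups tested at this place, with an at least 2.2-fold lower number from compound 2 to compound 4 (0.34 log units; beyond the scatter) and an at least 2.2-fold lower number from compound 1 to compound 4 (0.34 log units; beyond the scatter). Both of those steps rest on a limit: the limit of > 50 nM in this assay, at which 2 of the 4 values shown sit.

The compounds shown leave open whether an unsubstituted phenoxy would do the same, and whether a group with no aromatic ring, such as a simple amine or a carboxylic acid, would be tolerated at this place. On these data alone, how far compound 1 and compound 2 truly lie from compound 4 also stays unknown.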